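Chloro to fluoro on compound 3

This account rests on a few compounds, and the source may have more. Where it says the series, first, only, none or still open, it means among the compounds named here.

In a functional assay on HCT-116 cells (Homo sapiens) for antiproliferative activity, read by MTT assay, with a stated time of 72 h (on this read-out lower numbers stand for stronger inhibition and higher numbers for weaker inhibition), compound 1 (`NC1=NC2(CCSCC2)N(OCCCOc2ccc(Cl)c(Cl)c2)C(N)=N1`) gives 1 nM and compound 2 (`CC(C)(C)c1ccc(OCCCON2C(N)=NC(N)=NC23CCSCC3)cc1`) gives 1 nM. Compound 3 (`NC1=NC2(CCOCC2)N(OCCCOc2ccc(Cl)cc2)C(N)=N1`) gives 690 nM, the highest of the three numbers, and its gaps to both other compounds lie beyond the scatter. Going by the values given here, no two measured compounds differ in one place only, so the data hold no direct measure of any single change.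

Compound 4 (`NC1=NC2(CCOCC2)N(OCCCOc2ccc(F)cc2)C(N)=N1`) has fluoro in place of chloro on an aromatic carbon, para to a large group: fluoro in place of chloro on an aromatic carbon. Among the compounds with values here, with no measured precedent for this swap, the expectation stays close to compound 3 at 690 nM, leaning modestly toward weaker inhibition. The expected change in this assay is a 1.7-fold higher number from compound 3 to compound 4 (0.24 log units; within the scatter), which may not exceed the scatter. For compound 4 the estimate is 1200 nM, with an expected range of 350 nM to 4000 nM.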

Compound 4, half-maximal inhibitory concentration: 3280 nM
For compound 4 the middle estimate is 2.7-fold (0.44 log units) below the measured one; low and high end bracket the measured number.
By their numbers in this assay, from the lowest: compounds 1 and 2 (each within the scatter of the next); then compound 3; then compound 4.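

In this assay fluoro in place of chloro gives a 4.8-fold higher number from compound 3 to compound 4 (0.68 log units; beyond the scatter) and so provides the first direct measure of a single change in this series. The number at this aromatic carbon, para to a large group, therefore depends on which halogen sits there, and chloro gives the lower number of the two, though this is shown only for the pair formed by compound 3 and compound 4. No measurement at hand bears on the reason for this step.

Going by these compounds, whether a methoxy group, a trifluoromethyl group or a bare hydrogen at this position would extend the same trend stays open. Steps from compound 1 and compound 2 to the other compounds cannot be read, as they differ in more than one place, so it also stays open whether the swap would carry the same size on the core of compound 1.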